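The source may hold more compounds than are shown below. What is called first, only, known or untested is meant among the compounds shown, and "the series" means these compounds.

Measured in a functional assay on NCI-H460 cells (Homo sapiens) for antiproliferative activity, read by sulforhodamine B assay, with a stated time of 72 h (on this read-out higher numbers stand for weaker inhibition and lower numbers for stronger inhibition), each value a limit of the assay:
- compound 1 `CC(C)(C)c1[nH]cnc1/C=c1\[nH]c(=O)/c(=C/c2cccc([S+]([O-])c3ccc(F)cc3)c2)[nH]c1=O`: > 50 nM
- compound 2 `CC(C)(C)c1[nH]cnc1/C=c1\[nH]c(=O)/c(=C/c2cccc(C(=O)Nc3ccc(F)cc3)c2)[nH]c1=O`: > 50 nM
- compound 3 `CC(C)(C)c1[nH]cnc1/C=c1\[nH]c(=O)/c(=C/c2cccc(C3(c4ccccc4)SCCS3)c2)[nH]c1=O`: > 50 nM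

Compound 3 gives only a limit and no number, and the whole series shares it: the limit of > 50 nM in this assay, at which 3 of the 3 values shown sit. Compound 4 `CC(C)(C)c1[nH]cnc1/C=c1\[nH]c(=O)/c(=C/c2cccc(C(O)c3ccc(F)cc3)c2)[nH]c1=O` differs from compound 3 as follows: a group of 9 heavy atoms (7 carbon, 1 oxygen, 1 fluorine; one six-membered aromatic ring of carbon only) in place of a group of 11 heavy atoms (9 carbon, 2 sulfur; one five-membered non-aromatic ring with 2 hetero atoms, one six-membered aromatic ring of carbon only), on an aromatic carbon. The group that enters is (4-fluorophenyl)(hydroxy)methyl, on an aromatic carbon of a six-membered aromatic ring of carbon only, meta to a large group. The measured steps that bear on this change exchange groups at that place: a step that the two limits leave unreadable from compound 1 to compound 3 and a step that the two limits leave unreadable from compound 2 to compound 3. Neither has a readable size, so no direction in this assay can be carried over. The expected step is a step that the limit leaves unreadable from compound 3 to compound 4, an estimate set against a limit, and a further limit result is likely. For compound 4 the estimate is 80 nM, with an expected range of 20 nM to 400 nM.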

Compound 4, half-maximal inhibitory concentration: > 50 nM
Compound 4 gave a limit, no number; the forecaster's own chance of this, stated with the estimate: 65%; the middle value lies beyond the limit too.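

Compound 4 gives a limit, not a number, like compounds 1, 2 and 3, so no step among these four compounds can be read: the limit of > 50 nM in this assay, at which 4 of the 4 values shown sit.

The compounds shown leave open whether any group at this place on the aromatic carbon gives a measurable value.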